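Thiophene replaces chlorophenyl on a hydroxamic acid triazole

This account rests on a few compounds, and the source may have more. Where it says the series, first, only, none or still open, it means among the compounds named here.

Compound 2 `O=C(NO)c1ccc(NCc2nc(-c3ccccc3Cl)nn2-c2ccccc2)cc1` is the reference here. In an assay on Sf9 cells for inhibition of protein deacetylase HDAC6 (Homo sapiens), read by fluorescence, with a stated time of 40 min, tested at 100 nM (a higher number here means more inhibition at the concentration tested (going by the name of the read-out), a lower number less inhibition), compound 2 gives 75%, the highest of the three numbers shown. Compound 1 `O=C(NO)c1ccc(NCc2nc(-c3ccccn3)nn2-c2ccccc2)cc1` gives 58.6%, and the change from compound 1 to compound 2, 2-chlorophenyl in place of pyridin-2-yl on an aromatic carbon, gave a number 16.4 percentage points higher from compound 1 to compound 2 (beyond the scatter). Compound 3 `NNC(=O)c1ccc(NCc2nc(-c3ccccc3)nn2-c2ccccc2)cc1`, which carries a hydrazide instead of the hydroxamic acid, gives 10%, far lower than compound 2.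

Compound 4 `Cc1ccsc1-c1nc(CNc2ccc(C(=O)NO)cc2)n(-c2ccccc2)n1` differs from compound 2 as follows: 3-methylthiophen-2-yl in place of 2-chlorophenyl on an aromatic carbon. Among the measured compounds shown here, only the step from compound 1 to compound 2 touches this position, and it was modest; no measured step shows a five-membered ring entering at this place. A small step is therefore expected in this assay, more likely a slight drop than a rise, but possibly none beyond the scatter. For compound 4 the expected value in this assay is 65%, with a range from 45% to 85%. The expected step from compound 2 to compound 4 is a number 10 percentage points lower from compound 2 to compound 4 (within the scatter).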

Compound 4, a percentage reported as inhibition, at one concentration (the size of the read-out at that concentration, not a potency): 72.1%
For compound 4 the middle estimate is 7.1 percentage points below the measured one, and the stated range covers the measured number.
By their numbers in this assay, from the lowest: compound 3; then compound 1; then compounds 4 and 2 (each within the scatter of the next).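

In this assay, 3-methylthiophen-2-yl in place of 2-chlorophenyl gives a number 2.9 percentage points lower from compound 2 to compound 4 (within the scatter) and so shows that this position on the shared core can carry a five-membered aromatic ring with sulfur as well as a six-membered ring of carbon only. The same group gives a number 13.5 percentage points higher from compound 1 to compound 4 (beyond the scatter) in place of pyridin-2-yl, so a second replacement of pyridin-2-yl now raises the number, alongside the earlier a number 16.4 percentage points higher from compound 1 to compound 2 (beyond the scatter) step. Nothing at hand accounts for either result.

Open is what the methyl contributes, since the comparison with an unsubstituted thiophen-2-yl is missing from the compounds shown. Also open, from the compounds shown here alone, is whether a saturated ring such as cyclohexyl, or a ring with an amine such as piperidin-4-yl, would hold the number at this position.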